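Moving from methylamino to methoxy on the shared core

The compounds below may be only part of what the source reports. "The series", "measured", "known", "first", "only" and "open" are said of these compounds alone.

Of the compounds shown here, three of the shared core have been measured. Compound 1 `COc1ncnc2c1c(I)cn2[C@@H]1O[C@H](CO)[C@@H](O)[C@H]1O` carries iodo on the aromatic carbon and gives 14300 nM in a functional assay on HeLa S3 cells (Homo sapiens) for antiproliferative activity, read by XTT assay, with a stated time of 72 h; on this read-out higher numbers stand for weaker inhibition and lower numbers for stronger inhibition. Compound 2 `COc1ncnc2c1c(-c1ccccc1)cn2[C@@H]1O[C@H](CO)[C@@H](O)[C@H]1O` carries phenyl in the same place, and for compound 2 this assay reports only a limit, > 20000 nM. Compound 3 `CNc1ncnc2c1c(-c1ccoc1)cn2[C@@H]1O[C@H](CO)[C@@H](O)[C@H]1O` carries a furyl ring there and methylamino on the six-membered aromatic ring, and for compound 3 this assay again reports only a limit, > 20000 nM. Within the data shown here, the one measured step, an at least 1.3-fold higher number from compound 1 to compound 2 (0.14 log units; that floor lies within the scatter), is the only change with a number on both sides, and it is small. Compound 3 thus stands at the weak end of what has been measured, with the limit of > 20000 nM in this assay, at which 2 of the 3 values shown sit, marking where two of the three values rest.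

Compound 4 `COc1ncnc2c1c(-c1ccoc1)cn2[C@@H]1O[C@H](CO)[C@@H](O)[C@H]1O` differs from compound 3 by methoxy in place of methylamino on an aromatic carbon. Among the measured compounds shown here, no measured step covers this exchange, so the size expected for a step that the limit leaves unreadable from compound 3 to compound 4 in this assay is estimated as none beyond the scatter, with a good chance that only a limit is reported. Compound 4 is therefore expected to give 30000 nM in this assay, within 10000 nM to 100000 nM.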

Compound 4, half-maximal inhibitory concentration: 1790 nM
The estimate for compound 4 lay 17-fold (1.22 log units) above the measured number; the whole stated range lies above it.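

In this assay, the exchange of methylamino for methoxy on the aromatic carbon of the six-membered aromatic ring, with the furyl ring held constant, gives an at least 11-fold lower number from compound 3 to compound 4 (1.04 log units; beyond the scatter), so this position can decide whether the furyl compound registers a measured value at all. With methoxy held constant, furan-3-yl also separates clearly from the other two groups on the aromatic carbon, with an at least 11-fold lower number from compound 2 to compound 4 (1.04 log units; beyond the scatter) and an 8.0-fold lower number from compound 1 to compound 4 (0.90 log units; beyond the scatter), whereas the earlier exchange of iodo for phenyl gave only an at least 1.3-fold higher number from compound 1 to compound 2 (0.14 log units; that floor lies within the scatter), and compound 4 is the most potent of the four in this set. Compound 2 and compound 3 each carry only a limit, so the true size of the two steps that start from them stays unknown, and each printed size is only a floor: the limit of > 20000 nM in this assay, at which 2 of the 4 values shown sit.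

The compounds shown leave open whether the gain belongs to methoxy itself or would also appear with ethoxy, a methylthio group or an unsubstituted amine at this position. They also leave open whether a thiophene ring could take the place of the furyl ring, and they do not say why methoxy and furan-3-yl work well together.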